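Replacing the dimethoxyphenyl of compound 1 with chlorophenyl

A few compounds are considered here, and "the series" means these few. Any claim that something is new, unique, unknown or untested is made for them only; others in the source may bear on it.

Among the measured compounds shown here, compound 1 `COc1ccc(OC)c(/C=N/NC(=O)Nc2ccc(Oc3ccnc(-c4nncn4CCN(C)C)c3)c(F)c2)c1` is the only member of this set with a numeric result: in a functional assay on A549 cells (Homo sapiens) for cytotoxicity, read by MTT assay, with a stated time of 72 h (a higher number here means a weaker inhibitor, a lower number a stronger inhibitor), compound 1 gives 1950 nM. Compound 2 `COc1cc(/C=N/NC(=O)Nc2ccc(Oc3ccnc(-c4nncn4CCN(C)C)c3)c(F)c2)cc(OC)c1OC` carries a 3,4,5-trimethoxyphenyl in place of the 2,5-dimethoxyphenyl on the carbon with a double bond to nitrogen. In this assay compound 2 reaches only a limit of the assay, > 100000 nM, not a number. For compound 2 this is the limit of > 100000 nM in this assay, at which 1 of the 2 values shown sits. For the measured compounds named here, the one measured step is therefore an at least 51-fold higher number from compound 1 to compound 2 (1.70 log units; beyond the scatter), a large loss.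

Compound 3 `CN(C)CCn1cnnc1-c1cc(Oc2ccc(NC(=O)N/N=C/c3ccc(Cl)cc3)cc2F)ccn1` differs from compound 1 at the same carbon: 4-chlorophenyl in place of 2,5-dimethoxyphenyl on a carbon with a double bond to nitrogen. The measured step bears on this only indirectly, since it concerns a different replacement of the same ring, but it shows that the aryl group on that carbon can decide whether any activity remains at all in this assay. Given how sharply the ring change from compound 1 to compound 2 was felt, the step to compound 3 is estimated at a 1.8-fold higher number from compound 1 to compound 3 (0.25 log units; within the scatter), with wide uncertainty. Compound 3 is expected to give about 3500 nM, between 700 nM and 40000 nM.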

Compound 3, half-maximal inhibitory concentration: 780 nM
Compound 3: the middle estimate sits 4.5-fold (0.65 log units) above what was measured; the measured number falls inside the stated range.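

Compound 3 shows that the carbon with a double bond to nitrogen accepts a ring with no methoxy groups and no hydrogen-bond acceptors, and that in this assay the number improves with this change: the exchange of 2,5-dimethoxyphenyl for 4-chlorophenyl gives a 2.5-fold lower number from compound 1 to compound 3 (0.40 log units; beyond the scatter). So far this position had shown only a loss, and the exchange of 3,4,5-trimethoxyphenyl for 4-chlorophenyl now gives an at least 120-fold lower number from compound 2 to compound 3 (2.10 log units; beyond the scatter), which places the three aryl groups in a clear order, with 4-chlorophenyl giving the lowest number of the three. The size of that second step is only a bound, because compound 2 stands at a limit of the assay, not at a number: the limit of > 100000 nM in this assay, at which 1 of the 3 values shown sits.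

From the compounds shown here alone, what an unsubstituted phenyl or a 4-methoxyphenyl would give on this carbon remains open, so the part played by the chlorine cannot be separated from the part played by losing the methoxy groups. Also open, going by these compounds, are whether the chlorine would serve as well if replaced by a 4-bromophenyl or a 3-chlorophenyl, and whether the carbon needs an aromatic ring at all, as a cyclohexyl group would test.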